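This account rests on a few compounds, and the source may have more. Where it says the series, first, only, none or still open, it means among the compounds named here.

Three close relatives of one shared core have been tested in a functional assay on A549 cells (Homo sapiens) for inhibition, read by sulforhodamine B assay, with a stated time of 48 h; a lower number here means a stronger inhibitor, a higher number a weaker inhibitor. Compound 1 `Cc1ccc2occ(C3N=C(c4ccccc4)SS3)c(=O)c2c1` gives 66500 nM, compound 2 `O=c1c(C2N=C(c3ccccc3)SS2)coc2ccc(Cl)cc12` gives 71300 nM and compound 3 `O=c1c(C2N=C(c3ccccc3)SS2)coc2cc(Cl)c(Cl)cc12` gives 95000 nM. On these numbers compound 2 lies between the other two, yet both gaps are small: the step of a 1.1-fold higher number from compound 1 to compound 2 (0.03 log units; within the scatter) and the step of a 1.3-fold higher number from compound 2 to compound 3 (0.12 log units; within the scatter) each stay within the scatter, so the three compounds cannot be told apart in this assay. Compound 4 `O=c1c(C2N=C(c3ccccc3)SS2)coc2ccc(F)cc12` is a new member of the series, changed from compound 2 in one place: fluoro in place of chloro on an aromatic carbon. The two measured steps both concern a small group on an aromatic carbon of the core, and neither shifted the number beyond the scatter. Putting fluoro in place of chloro is therefore expected to leave this assay near where compound 2 sits, with no step beyond the scatter in either direction. For compound 4 the expected value is 75000 nM, within a range from 40000 nM to 150000 nM. The step this estimate implies, a 1.1-fold higher number from compound 2 to compound 4 (0.02 log units; within the scatter), is expected to remain within the scatter.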

Compound 4, half-maximal inhibitory concentration: 91100 nM
Beside the measured number, compound 4's estimate is 1.2-fold (0.08 log units) below it; low and high end bracket the measured number.
By their numbers in this assay, from the lowest: compounds 1, 2, 4 and 3 (each within the scatter of the next).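

In this assay, the change from chloro to fluoro on this aromatic carbon gives a step (a 1.3-fold higher number from compound 2 to compound 4 (0.11 log units; within the scatter)) that does not separate the two compounds. Together with the step from methyl to fluoro at the same carbon (a 1.4-fold higher number from compound 1 to compound 4 (0.14 log units; within the scatter)), it means that three different groups have now been compared at this one position, and methyl, chloro and fluoro cannot be told apart there. Nothing shown explains why the assay does not distinguish these groups.

On these data alone, whether an amine, a carboxylic acid or a longer chain on this carbon would move the number beyond the scatter remains open. As far as these compounds go, what a change elsewhere on the shared core would do also remains open.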